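This account rests on a few compounds, and the source may have more. Where it says the series, first, only, none or still open, it means among the compounds named here.

Three compounds share one core and differ only in the group on a carbon with a double bond to nitrogen. In a functional assay on U-87MG ATCC cells (Homo sapiens) for cytotoxicity, read by MTT assay, with a stated time of 72 h (a higher number here means a weaker inhibitor, a lower number a stronger inhibitor), compound 1 `COc1ccc(OC)c(/C=N/NC(=O)Nc2ccc(Oc3ccnc(-c4nncn4CCN(C)C)c3)c(F)c2)c1` gives 6400 nM. In this assay compound 3 `CN(C)CCn1cnnc1-c1cc(Oc2ccc(NC(=O)N/N=C/c3ccccc3)cc2F)ccn1` gives 2250 nM. Among the measured compounds shown here, compound 2 `CN(C)CCn1cnnc1-c1cc(Oc2ccc(NC(=O)N/N=C/c3cc(Br)c(O)c(Br)c3)cc2F)ccn1` reaches in this assay only a limit, > 100000 nM, and no number, the single value sitting at the limit of > 100000 nM in this assay, at which 1 of the 3 values shown sits. Compound 2 therefore stands apart from both others, through an at least 15-fold higher number from compound 1 to compound 2 (1.19 log units; beyond the scatter) and an at least 44-fold lower number from compound 2 to compound 3 (1.64 log units; beyond the scatter). Compound 4 `CN(C)CCn1cnnc1-c1cc(Oc2ccc(NC(=O)N/N=C/c3ccc(O)cc3O)cc2F)ccn1` is not yet measured; it differs from compound 2 by 2,4-dihydroxyphenyl in place of 3,5-dibromo-4-hydroxyphenyl on a carbon with a double bond to nitrogen. Since compound 2 sat far from compound 1 by an at least 15-fold higher number from compound 1 to compound 2 (1.19 log units; beyond the scatter) and from compound 3 by an at least 44-fold lower number from compound 2 to compound 3 (1.64 log units; beyond the scatter), compound 4 is expected to fall back toward them, by an at least 11-fold lower number from compound 2 to compound 4 (1.04 log units; beyond the scatter). In this assay compound 4 is estimated at 9000 nM, between 2000 nM and 60000 nM.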

Compound 4, half-maximal inhibitory concentration: 15400 nM
Compound 4: middle estimate off by 1.7-fold (0.23 log units), on the low side, within the range that was stated.
By their numbers in this assay, from the lowest: compound 3; then compound 1; then compound 4. At a limit, above all of these: compound 2.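

In this assay, 2,4-dihydroxyphenyl in place of 3,5-dibromo-4-hydroxyphenyl gives an at least 6.4-fold lower number from compound 2 to compound 4 (0.81 log units; beyond the scatter) and restores a measurable number, so a hydroxyl on the phenyl does not by itself lead to a limit at this position. The new group still ranks behind phenyl, with a 6.8-fold higher number from compound 3 to compound 4 (0.84 log units; beyond the scatter) and with a 2.4-fold higher number from compound 1 to compound 4 (0.38 log units; beyond the scatter) as well, which leaves unsubstituted phenyl with the lowest number. Compound 2 remains a limit and not a number: the limit of > 100000 nM in this assay, at which 1 of the 4 values shown sits.

The two groups differ in both bromine and hydroxyl pattern, so the compounds shown do not separate these two changes. From the compounds shown here alone, how an amine or a carboxylic acid on the phenyl would behave also stays open.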